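A few compounds are considered here, and "the series" means these few. Any claim that something is new, unique, unknown or untested is made for them only; others in the source may bear on it.

Compound 1 `Cc1ccccc1-n1nncc1CN1C(=O)C2(C(C#N)=C(N)Oc3c2c2nc4ccccc4nc2c2ccccc32)c2ccccc21` was examined in an ADME assay on L02 cells (Homo sapiens) for antiproliferative activity, read by MTT assay, with a stated time of 48 h (a higher number here means a weaker inhibitor, a lower number a stronger inhibitor), where compound 1 gives only a limit, > 50000 nM. Two close relatives, compound 2 `N#CC1=C(N)Oc2c(c3nc4ccccc4nc3c3ccccc23)C12C(=O)N(Cc1cnnn1-c1ccc(Br)cc1)c1ccccc12` and compound 3 `N#CC1=C(N)Oc2c(c3nc4ccccc4nc3c3ccccc23)C12C(=O)N(Cc1cnnn1-c1ccccc1Br)c1ccccc12`, were run in the same way. In this assay compound 2 likewise gives only a limit, > 50000 nM. In this assay compound 3 also gives only a limit, > 50000 nM. The steps a step that the two limits leave unreadable from compound 1 to compound 2, a step that the two limits leave unreadable from compound 1 to compound 3 and a step that the two limits leave unreadable from compound 2 to compound 3 therefore cannot be sized, since (the limit of > 50000 nM in this assay, at which 3 of the 3 values shown sit). Compound 4 `CCOc1ccccc1-n1nncc1CN1C(=O)C2(C(C#N)=C(N)Oc3c2c2nc4ccccc4nc2c2ccccc32)c2ccccc21` differs from compound 1 by ethoxy in place of methyl on an aromatic carbon. For the measured compounds named here, no measured step bears on this change, and nothing points away from the limit. The step from compound 1 to compound 4 is expected to be a step that the limit leaves unreadable from compound 1 to compound 4, and compound 4 is estimated at 60000 nM, between 30000 nM and 150000 nM, most probably again reported only as a limit.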

Compound 4, half-maximal inhibitory concentration: > 50000 nM
Compound 4: no number, only a limit; the forecaster's own chance of this, stated with the estimate: 85%; the middle value does not contradict the limit.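

The steps joining compound 4 to compound 1, compound 2 and compound 3 cannot be read, as compound 4 also gives only a limit: the limit of > 50000 nM in this assay, at which 4 of the 4 values shown sit.

Going by these compounds, how far these four compounds truly lie apart in this assay stays open.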